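Oxime variation on the shared diaryl sulfide core

The source may hold more compounds than are shown below. What is called first, only, known or untested is meant among the compounds shown, and "the series" means these compounds.

Among the measured compounds shown here, compound 2 `O/N=C(/c1ccc(Sc2cc(F)cc(C3CCOCC3)c2)cc1)C(F)(F)F` gives 280 nM in a functional assay (blood) for inhibition, with Homo sapiens as the target (a lower number here means a stronger inhibitor, a higher number a weaker inhibitor), the lowest of the two numbers measured so far. Compound 1 `COC(=O)C(C)(C)CO/N=C(\C)c1ccc(Sc2cc(F)cc(C3CCOCC3)c2)cc1` gives 420 nM in this assay and lies within the scatter of compound 2, so no order between the two is claimed. Compound 3 `C/C(=N\OC(C)C)c1ccc(Sc2cc(F)cc(C3CCOCC3)c2)cc1` is not yet measured. It differs from compound 2 in one place: a group of 7 heavy atoms (5 carbon, 1 nitrogen, 1 oxygen; no ring) in place of a group of 7 heavy atoms (2 carbon, 1 nitrogen, 1 oxygen, 3 fluorine; no ring), on an aromatic carbon. For the measured compounds named here, no step between measured compounds differing in one place is available to guide the size of this change. Compound 3 is expected near 350 nM, with a range of 150 nM to 800 nM. The expected step of a 1.3-fold higher number from compound 2 to compound 3 (0.10 log units; within the scatter) is not expected to exceed the scatter.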

Compound 3, half-maximal inhibitory concentration: 920 nM
Beside the measured number, compound 3's estimate is 2.6-fold (0.42 log units) below it; the measured number lies above the stated range.
By their numbers in this assay, from the lowest: compounds 2 and 1 (each within the scatter of the next); then compound 3.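

In this assay, this position now shows a step beyond the scatter: the change at the aromatic carbon gives a 3.3-fold higher number from compound 2 to compound 3 (0.52 log units; beyond the scatter), and the group entering carries 0 hydrogen-bond donors against 1 in the group leaving. The substituent on the oxygen also moves the number, since isopropyl in place of 2-(methoxycarbonyl)-2-methylpropyl gives a 2.2-fold higher number from compound 1 to compound 3 (0.34 log units; beyond the scatter). Nothing available explains either step.

As far as these compounds go, compound 2 and compound 3 differ in both the trifluoromethyl and the oxygen substituent, so the share of each stays open. Also open, from the compounds shown here alone, is how a carboxylic acid or an amine on the oxygen chain would read.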